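Swapping phenyl for tert-butyl on a hydroxyacyl side chain

The source may hold more compounds than are shown below. What is called first, only, known or untested is meant among the compounds shown, and "the series" means these compounds.

Measured compounds:
compound 1 `O=C(NCc1cc(Cl)ccc1-n1cnnn1)[C@@H]1CC=NN1C(=O)[C@H](O)c1ccccc1`: 840 nM
compound 2 `O=C(NCc1cc(Cl)ccc1-n1cnnn1)[C@@H]1CCNN1C(=O)[C@H](O)c1ccccc1`: 930 nM
compound 3 `CC(C)(C)[C@@H](O)C(=O)N1N=CC[C@H]1C(=O)NCc1cc(Cl)ccc1-n1cnnn1`: 1400 nM

All three were tested in a functional assay on a cell-free system (plasma, Homo sapiens), with a stated time of 3 min; a lower number here means a stronger inhibitor, a higher number a weaker inhibitor. Compound 1 and compound 3 share one core and differ in a single spot: tert-butyl in place of phenyl on a saturated chain carbon bound to a carbonyl carbon and an oxygen on a saturated carbon. That change gave a 1.7-fold higher number from compound 1 to compound 3 (0.22 log units; within the scatter), so the two compounds read essentially alike. Compound 2 carries a different core from compound 1; the difference between the two cores is not broken down here, and their values in this assay sit close together.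

Compound 4 `CC(C)(C)[C@@H](O)C(=O)N1NCC[C@H]1C(=O)NCc1cc(Cl)ccc1-n1cnnn1` has not been measured yet. It stands to compound 2 as compound 3 stands to compound 1: tert-butyl in place of phenyl on a saturated chain carbon bound to a carbonyl carbon and an oxygen on a saturated carbon. The place of the change is described in exactly the same words in both pairs, so this is the same change on a second core.

Because compound 3 came out at a 1.7-fold higher number from compound 1 to compound 3 (0.22 log units; within the scatter), a step of about a 1.6-fold higher number from compound 2 to compound 4 (0.21 log units; within the scatter) is expected from compound 2 to compound 4. On that basis compound 4 is estimated to give 1500 nM in this assay, most likely between 800 nM and 3000 nM.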

Compound 4, half-maximal inhibitory concentration: 1700 nM
The estimate for compound 4 lay 1.1-fold (0.05 log units) below the measured number; low and high end bracket the measured number.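

In this assay, putting tert-butyl in place of phenyl on the second core gave a 1.8-fold higher number from compound 2 to compound 4 (0.26 log units; within the scatter), so this pair also reads essentially alike. The swap behaved the same way on both cores: the same change on two cores in this assay, a 1.7-fold higher number (0.22 log units; within the scatter) from compound 1 to compound 3 and a 1.8-fold higher number (0.26 log units; within the scatter) from compound 2 to compound 4, 1.1-fold (0.04 log units) apart, within the scatter of two such steps This shows that, across these four compounds, the change carries over from one core to the other, but neither step can be told apart from the scatter, so the agreement is between two steps too small to read and does not show that a change with a large effect would carry over in the same way, or that the result would hold on any further core.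

The compounds shown leave open how a cyclohexyl ring, a carboxylic acid or a longer chain would read in the place of phenyl or tert-butyl. Every compound shown also keeps the hydroxy group on that chain carbon, so what a side chain with an amine there would do remains open too.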